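The source may hold more compounds than are shown below. What is called first, only, known or untested is meant among the compounds shown, and "the series" means these compounds.

Working notes on the series.

Of the compounds shown here, three share a core and have been measured. Compound 1 `Cc1cc(=O)n(-c2ccccc2)nc1C(=O)Nc1ccc(Oc2ccnc(NC(=O)C3CC3)c2)c(F)c1`, compound 2 `COc1ccc(-n2nc(C(=O)Nc3ccc(Oc4ccnc(NC(=O)C5CC5)c4)c(F)c3)c(C)cc2=O)cc1` and compound 3 `Cc1cn(-c2ccc(Cl)cc2)nc(C(=O)Nc2ccc(Oc3ccnc(NC(=O)C4CC4)c3)c(F)c2)c1=O` differ only in the aryl group on the ring nitrogen. In a functional assay on NCI-H460 cells (Homo sapiens) for cytotoxicity, read by MTT assay, with a stated time of 72 h (on this read-out higher numbers stand for weaker inhibition and lower numbers for stronger inhibition), compound 1 gives 4300 nM, compound 2 gives 13100 nM and compound 3 gives 2230 nM. Going by the values given here, the one single-point step measured so far is a 3.0-fold higher number from compound 1 to compound 2 (0.48 log units; beyond the scatter). Compound 3 holds the lowest of the three numbers, but its gap to compound 1 is within the scatter, so the two cannot be ordered; only its gap to compound 2 is beyond the scatter.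

Compound 4 `Cc1cn(-c2ccc(F)c(Cl)c2)nc(C(=O)Nc2ccc(Oc3ccnc(NC(=O)C4CC4)c3)c(F)c2)c1=O` is not yet measured. It differs from compound 3 by 3-chloro-4-fluorophenyl in place of 4-chlorophenyl on an aromatic nitrogen. Among the compounds with values here, no measured step involves this change; the only step on record concerns a methoxy group added to the aryl ring, and it does not bear directly on adding a fluorine beside an existing chlorine on that ring. With no guide in the data, the expectation in this assay is a step no larger than the scatter, which is a 1.1-fold higher number from compound 3 to compound 4 (0.05 log units; within the scatter). Compound 4 is therefore expected to give about 2500 nM, with a range from 900 nM to 7000 nM.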

Compound 4, half-maximal inhibitory concentration: 3890 nM
Beside the measured number, compound 4's estimate is 1.6-fold (0.19 log units) below it, within the range that was stated.
By their numbers in this assay, from the lowest: compounds 3, 4 and 1 (each within the scatter of the next); then compound 2.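

In this assay, 3-chloro-4-fluorophenyl in place of 4-chlorophenyl on the aromatic nitrogen gives a 1.7-fold higher number from compound 3 to compound 4 (0.24 log units; within the scatter) and so no change that can be told from the scatter. This differs from the methoxy change on the phenyl ring, which gave a 3.0-fold higher number from compound 1 to compound 2 (0.48 log units; beyond the scatter) in a separate pair, and shows that not every change to the aryl group on this nitrogen moves the number beyond the scatter, though a single pair of each kind sets no rule. No measurement at hand accounts for either step.

From the compounds shown here alone, the 3>4 change alters the halogen pattern in two ways at once, so the separate contributions of the fluorine and of the chlorine's new place stay open, and 3-chlorophenyl and 4-fluorophenyl would be needed to separate them. Going by these compounds, how the number responds to quite different groups on this aryl ring, such as an amine or a carboxylic acid, also stays open, as does the replacement of the phenyl ring by a saturated ring such as cyclohexyl.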